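The source may report more compounds than this note shows. Statements on the series, on what has been measured and on what is new or still open speak of the compounds shown alone.

Measured so far:
compound 1 `CCCCSc1nsnc1C1CN2CCCC1C2` gives 0.03 mg/kg in a functional assay on the whole organism with Mus musculus as the target, in the writhing test; on this read-out higher numbers stand for an effect only at larger amounts of compound and lower numbers for an effect already at smaller amounts.
Compound 2 `CC(C)CCCSc1nsnc1C1CN2CCCC1C2` gives 0.95 mg/kg in this assay.
Compound 3 `FC(F)(F)CCCSc1nsnc1[C@@H]1CN2CCC[C@H]1C2` reaches only the limit of > 10 mg/kg in this assay.

Of the two numbers given, compound 1 has the lowest; the nearest is compound 2, with a 32-fold higher number from compound 1 to compound 2 (1.50 log units; beyond the scatter), the change being isopropyl in place of methyl on a saturated chain carbon, three bonds along the chain from a sulfur. Compound 4 `CCCCSc1nsnc1[C@@H]1CN2CCC[C@@H]1C2` has the same atoms and bonds as compound 1; (the two compounds have the same atoms and bonds; at least one stereo element is drawn with a configuration in one of them and without one in the other: 2 of 3 stereo elements differ; a stereocentre at a saturated ring carbon is drawn without a configuration in compound 1 and S in compound 4; a stereocentre at a saturated ring carbon is drawn without a configuration in compound 1 and S in compound 4). Within the data shown here, no measured step changes only the drawn configuration: the step from compound 1 to compound 2 alters the chain, and compound 3 differs in both chain and configuration, so neither bears directly on this change. Among the measured compounds shown here, with no comparable step, no change beyond the scatter is expected, though a single configuration could turn out to act at smaller amounts. Compound 4 is therefore estimated at 0.03 mg/kg, within 0.008 mg/kg to 0.3 mg/kg, which is expected to mean no change at the digits printed from compound 1 to compound 4 (within the scatter).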

Compound 4, dose for half-maximal effect: 0.19 mg/kg
Compound 4: middle estimate off by 6.3-fold (0.80 log units), on the low side; measured number inside the range.
By their numbers in this assay, from the lowest: compound 1; then compound 4; then compound 2. At a limit, above all of these: compound 3.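

Drawing a defined configuration at the two saturated ring carbons, with nothing else altered, changes the result in this assay: the step is a 6.3-fold higher number from compound 1 to compound 4 (0.80 log units; beyond the scatter). So these stereocentres matter at this position, which the earlier chain step could not show. The step still cannot be tied to one configuration alone, since it sets a defined drawing against an undefined one: the fact that one of compounds 1 and 4 is drawn with a defined configuration and the other without, at the place where they differ

Open, from the compounds shown here alone, is how the other configurations would read with this same chain, and whether one of them accounts for the low number of compound 1. Also open, going by these compounds, is how a longer chain or a terminal amine would behave on the configuration of compound 4.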